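Clearance notes on compound 3 and compound 4

The compounds below may be only part of what the source reports. "The series", "measured", "known", "first", "only" and "open" are said of these compounds alone.

Compound 1: `CC(=O)N/N=C(\C)c1nc([C@@H](O)[C@H](O)[C@H](O)CO)c[nH]1` gives 8.9 mL/min/kg
Compound 2: `OC[C@@H](O)[C@@H](O)[C@H](O)c1c[nH]c(C(F)(F)C(F)(F)F)n1` gives 1.3 mL/min/kg
Compound 3: `Cc1nc(-c2nc([C@@H](O)[C@H](O)[C@H](O)CO)c[nH]2)cs1` gives 19.4 mL/min/kg

In an in vivo ADME assay on the whole organism (strain 129/SvEvBrd x C57BL/6) for pharmacokinetics, with Mus musculus as the target, at a dose of 1 mg/kg by the intravenous route (on this read-out lower numbers stand for slow clearance and higher numbers for fast clearance), compound 3 stands highest of the three, and its gaps to compound 1 and compound 2 both lie beyond the scatter. Compound 4 `OC[C@@H](O)[C@@H](O)[C@H](O)c1c[nH]c(-c2ncon2)n1` carries 1,2,4-oxadiazol-3-yl in place of 2-methyl-1,3-thiazol-4-yl on an aromatic carbon, between two ring nitrogen atoms. Going by the values given here, no measured pair differs in this one place alone, so the expectation rests only on the spread of the values. Compound 3 (19.4 mL/min/kg) sits at the top of that spread, above compound 1 (8.9 mL/min/kg) and compound 2 (1.3 mL/min/kg), so a move down is more likely than a move up. The estimated step is a fall a 2.4-fold lower number from compound 3 to compound 4 (0.38 log units; beyond the scatter) and would lie beyond the scatter, although its size is poorly defined by so few compounds. The estimate for compound 4 is 8 mL/min/kg (expected range 2.5 mL/min/kg to 22 mL/min/kg).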

Compound 4, clearance: 11.3 mL/min/kg
Estimate against measurement, compound 4: 1.4-fold (0.15 log units) below; low and high end bracket the measured number.
By their numbers in this assay, from the lowest: compound 2; then compounds 1, 4 and 3 (each within the scatter of the next, the first and the last beyond it).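

In this assay, going by these compounds alone, 1,2,4-oxadiazol-3-yl in place of 2-methyl-1,3-thiazol-4-yl on this aromatic carbon, between two ring nitrogen atoms, gives a 1.7-fold lower number from compound 3 to compound 4 (0.23 log units; within the scatter) and provides the first direct reading of a single change at this place. On this one pair, the two five-membered aromatic rings cannot be told apart, even though they differ in heavy atoms, hetero atoms and hydrogen-bond acceptors. No measured evidence on the cause of this result is at hand.

Going by these compounds, whether an amine, a carboxylic acid or a longer alkyl chain on this carbon would move clearance beyond the scatter from compound 3 stays open. Also open, on these data alone, is what a methyl group on the 1,2,4-oxadiazol-3-yl ring would do, so the methyl group and the ring remain unseparated.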